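The source may hold more compounds than are shown below. What is called first, only, known or untested is meant among the compounds shown, and "the series" means these compounds.

Compound 2 `CCCCCc1cn(C(c2ccccc2)c2cc3cc(Br)ccc3nc2OC)nn1` gives -2% in an ADME assay on HEK293 cells (Homo sapiens) for cytotoxicity, read by sulforhodamine B assay, with a stated time of 48 h, tested at 10 uM (a higher number here means more inhibition at the concentration tested (going by the name of the read-out), a lower number less inhibition), the lowest of the three numbers at hand. Compound 3 `CCCc1cn(C(c2ccccc2)c2cc3cc(Br)ccc3nc2OC)nn1` gives 0.85%, and the step of a number 2.9 percentage points higher from compound 2 to compound 3 (within the scatter) lies within the scatter. Compound 1 `COc1nc2ccc(Br)cc2cc1C(c1ccccc1)n1cc(-c2ccccc2)nn1` gives 8.25%, and the step of a number 10.3 percentage points lower from compound 1 to compound 2 (beyond the scatter) is the only one that reaches beyond the scatter. Compound 4 `COc1nc2ccc(Br)cc2cc1C(c1ccccc1)n1cc(CCCCCO)nn1` differs from compound 2 in one place: hydroxy in place of hydrogen on a saturated chain carbon, five bonds along the chain from an aromatic carbon. Among the measured compounds shown here, none of the measured steps touches a hydroxy group; they all exchange the group on the aromatic carbon, and two of them stay within the scatter. For the measured compounds named here, no measured step therefore points to a sizeable shift, and the estimated step of a number 4 percentage points higher from compound 2 to compound 4 (within the scatter) is expected to stay within the scatter. For compound 4 the expected value is 2%, estimated to fall between -8% and 12%.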

Compound 4, a percentage reported as inhibition, at one concentration (the size of the read-out at that concentration, not a potency): 7.96%
The estimate for compound 4 lay 6 percentage points below the measured number; the range from low to high includes it.
By their numbers in this assay, from the lowest: compounds 2, 3, 4 and 1 (each within the scatter of the next, the first and the last beyond it).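

In this assay, hydroxy on the saturated chain carbon five bonds along the chain from an aromatic carbon gives a number 10 percentage points higher from compound 2 to compound 4 (within the scatter) and stays within the scatter, so this first polar-labelled change... 

Corrected version:

In this assay, hydroxy in place of hydrogen, five bonds along the chain from an aromatic carbon, gives a number 10 percentage points higher from compound 2 to compound 4 (within the scatter) and so leaves no readable change at this position. The comparison with the propyl chain gives a number 7.1 percentage points higher from compound 3 to compound 4 (within the scatter) and that with phenyl gives a number 0.3 percentage points lower from compound 1 to compound 4 (within the scatter) and both also stay within the scatter, so 5-hydroxypentyl cannot be told apart from any of the three other groups. No measurement explains these numbers. Going by these compounds, whether an amine, a carboxylic acid or a longer chain at this position would move the number beyond the scatter stays open.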